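From a Chlorinated Chain to an Oxygen Ring

The source may hold more compounds than are shown below. What is called first, only, known or untested is meant among the compounds shown, and "the series" means these compounds.

Compound 1 `Nc1ncnc2c1ncn2C/C=C\CCl`: 22000 nM
Compound 2 `Nc1ncnc2c1ncn2CC#CCCl`: 90000 nM

In a functional assay on L1210 cells (Mus musculus) for inhibition (a lower number here means a stronger inhibitor, a higher number a weaker inhibitor), compound 2 gives the higher of the two numbers, 90000 nM, which makes it the weaker inhibitor of this pair. The gap is a 4.1-fold higher number from compound 1 to compound 2 (0.61 log units; beyond the scatter).

Compound 3 `Nc1ncnc2c1ncn2C1C=CCO1` has not yet been measured. The change from compound 2 is a group of 5 heavy atoms (4 carbon, 1 oxygen; one five-membered non-aromatic ring with 1 hetero atom) in place of a group of 5 heavy atoms (4 carbon, 1 chlorine; no ring), on an aromatic nitrogen. In plain terms, the 4-chlorobut-2-yn-1-yl chain leaves, and a group with one five-membered non-aromatic ring enters on the same aromatic nitrogen.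

Within the data shown here, the single measured step, a 4.1-fold higher number from compound 1 to compound 2 (0.61 log units; beyond the scatter), offers only a loose guide, since it swapped one chlorine-bearing chain for another. Among the measured compounds shown here, no measured compound lacks the chlorine or carries a ring at this place, so the data cannot fix a direction with confidence. A modest step is therefore the most that can be argued, and no step beyond the scatter is expected in this assay. The expected change is a 1.3-fold higher number from compound 2 to compound 3 (0.12 log units; within the scatter), a slight lean towards a higher number. For compound 3 the estimated value is 120000 nM, with an expected range from 40000 nM to 400000 nM.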

Compound 3, half-maximal inhibitory concentration: > 500000 nM
Compound 3 was reported as a limit; the forecaster's own chance of this, stated with the estimate: 35%; middle value at least 4.1-fold (0.61 log units) from the limit.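

In this assay compound 3 gives > 500000 nM, which is a limit of the assay and not a number, and it is the only limit here: the limit of > 500000 nM in this assay, at which 1 of the 3 values shown sits.

Replacing the 4-chlorobut-2-yn-1-yl chain with the five-membered oxygen ring on the same aromatic nitrogen gives an at least 5.5-fold higher number from compound 2 to compound 3 (0.74 log units; beyond the scatter), and the comparison with the other chlorine-bearing chain gives an at least 22-fold higher number from compound 1 to compound 3 (1.35 log units; beyond the scatter). The two chains alone showed a modest difference, whereas these steps show that inhibition in this cell assay is not indifferent to what sits on this nitrogen, and that this ring, with no chlorine, gives the weakest inhibitor of the three, with both of its steps printed as beyond the scatter.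

The chlorine leaves and the ring enters in one change, so the compounds shown leave open which of the two accounts for the loss, and how far compound 3 really lies beyond its limit. An open 4-hydroxybut-2-yn-1-yl chain, with a hydroxyl group where the chlorine stands, would separate the two, since it would remove the chlorine while keeping the chain.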